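Closing a Dipropylamino Chain into a Seven-Membered Ring

This account rests on a few compounds, and the source may have more. Where it says the series, first, only, none or still open, it means among the compounds named here.

Compound 1 `CCCN(CCC)c1nc(C(F)(F)F)ccc1CNC(=O)C(C)c1ccc(NS(C)(=O)=O)c(F)c1` is the starting point. Within the data shown here, in a functional assay on CHO-K1 cells for antagonist activity at transient receptor potential cation channel subfamily V member 1 (Homo sapiens), read by FLIPR (on this read-out lower numbers stand for stronger inhibition and higher numbers for weaker inhibition), compound 1 gives 0.2 nM, the lower of the two numbers measured so far. Among the measured compounds shown here, the only other measured compound, compound 2 `C[C@H](C(=O)NCc1ccc(C(F)(F)F)nc1N1CC[C@H](N(C)C)C1)c1ccc(NS(C)(=O)=O)c(F)c1`, carries a different group on the shared core and gives 103 nM in this assay, a far higher number, well beyond the usual scatter. For the measured compounds named here, no step between measured compounds that differ in a single place is available, so nothing can be read directly from pairs. Compound 3 `CC(C(=O)NCc1ccc(C(F)(F)F)nc1N1CCCCCC1)c1ccc(NS(C)(=O)=O)c(F)c1` has not been measured. It differs from compound 1 in one place: azepan-1-yl in place of dipropylamino on an aromatic carbon. The group that enters matches the one that leaves in what is counted, only tied into a ring. For compound 3 the expected step of a 2.0-fold higher number from compound 1 to compound 3 (0.30 log units; within the scatter) is small, with no clear direction beyond the scatter. Compound 3 is therefore expected to give about 0.4 nM in this assay, most likely between 0.1 nM and 2 nM.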

Compound 3, inhibition constant: 0.8 nM
Compound 3: middle estimate off by 2.0-fold (0.30 log units), on the low side; low and high end bracket the measured number.
By their numbers in this assay, from the lowest: compound 1; then compound 3; then compound 2.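

Tying the dipropylamino chains into azepan-1-yl keeps the same count of heavy atoms, yet it gives a 4.0-fold higher number from compound 1 to compound 3 (0.60 log units; beyond the scatter) in this assay, so on this aromatic carbon the open and closed forms are not interchangeable. The step is modest, and compound 3 still gives 0.8 nM as a low number on this read-out, so this position accepts a seven-membered ring with only a limited loss of inhibition. No measurement available here explains why closing the ring raises the number.

On these data alone, it remains open whether this rise belongs to ring closure itself or to this particular ring size, which a piperidin-1-yl or pyrrolidin-1-yl group at the same place could help separate. A morpholine ring, with an oxygen in the ring, or a shorter diethylamino group would show how much further this position can be changed.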